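The compounds below may be only part of what the source reports. "The series", "measured", "known", "first", "only" and "open" are said of these compounds alone.

Working notes on the series built on the shared core of compound 1 `CN1CCC(c2c[nH]c3ccc(NC(=O)c4cccs4)nc23)CC1`. In an assay for binding affinity to 5-hydroxytryptamine receptor 1F (Homo sapiens), read by radioligand binding (a higher number here means a weaker inhibitor, a lower number a stronger inhibitor), compound 1 gives 7.1 nM. Compound 2 `CCCC(=O)Nc1ccc2[nH]cc(C3CCN(C)CC3)c2n1` gives 6.9 nM in this assay, and compound 3 `CCCCC(=O)Nc1ccc2[nH]cc(C3CCN(C)CC3)c2n1` gives 14 nM. Within the data shown here, compound 3 thus carries the highest of the three numbers, though only the step of a 2.0-fold higher number from compound 2 to compound 3 (0.31 log units; beyond the scatter) is a real difference; the step of a 2.0-fold higher number from compound 1 to compound 3 (0.29 log units; within the scatter) is not.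

Compound 4 `CN1CCC(c2c[nH]c3ccc(OS(C)(=O)=O)nc23)CC1` differs from compound 3 by (methylsulfonyl)oxy in place of (butylcarbonyl)amino on an aromatic carbon. The measured steps of a 1.0-fold lower number from compound 1 to compound 2 (0.01 log units; within the scatter), a 2.0-fold higher number from compound 1 to compound 3 (0.29 log units; within the scatter) and a 2.0-fold higher number from compound 2 to compound 3 (0.31 log units; beyond the scatter) all exchange one substituent on the carbonyl for another while keeping the amide itself, and all stay at or near the scatter. Among the measured compounds shown here, no step here replaces the whole amide, nor removes its hydrogen-bond donor, so the change to compound 4 is not covered by the data, and a step in either direction beyond the scatter cannot be excluded. With the amide gone, the expectation for compound 4 is a weaker binder, the step of a 3.2-fold higher number from compound 3 to compound 4 (0.51 log units; beyond the scatter) being an estimate. Compound 4 is estimated at 45 nM in this assay, within a range of 8 nM to 250 nM.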

Compound 4, inhibition constant: 4.7 nM
Estimate against measurement, compound 4: 9.6-fold (0.98 log units) above; the whole stated range lies above it.
By their numbers in this assay, from the lowest: compounds 4, 2, 1 and 3 (each within the scatter of the next, the first and the last beyond it).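

In this assay the amide on this aromatic carbon, next to the ring nitrogen, proves replaceable as a whole: (methylsulfonyl)oxy, which has no amide hydrogen, keeps binding in the same range as the amides. The exchange gives a 1.5-fold lower number from compound 2 to compound 4 (0.17 log units; within the scatter) and a 1.5-fold lower number from compound 1 to compound 4 (0.18 log units; within the scatter) so those two pairs stay level, and a 3.0-fold lower number from compound 3 to compound 4 (0.47 log units; beyond the scatter) is the one real difference, in favour of the sulfonate ester. No measurement is at hand that explains this result.

The compounds shown do not separate the loss of the amide hydrogen from the loss of the carbonyl, which an N-methyl amide or a methanesulfonamide at the same carbon would address. Also open, on these data alone, is whether a plain amine, a methoxy group or a longer chain on the sulfonyl group would hold binding at this position.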